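The source may hold more compounds than are shown below. What is called first, only, known or untested is meant among the compounds shown, and "the series" means these compounds.

Measured compounds:
- compound 1, `CC1(C)OC[C@@H](C/C=C\CCC(=O)O)[C@@H](c2cccnc2)O1`: 120 nM
- compound 2, `CC1(C)OC[C@@H](C/C=C\CCC(=O)O)[C@@H](c2cnccn2)O1`: > 10000 nM
- compound 3, `CC1(C)OC[C@@H](C/C=C\CCC(=O)O)[C@@H](c2cnco2)O1`: > 10000 nM

In an assay on isolated protein for inhibition of Thromboxane-A synthase (Homo sapiens) (a lower number here means a stronger inhibitor, a higher number a weaker inhibitor), compound 1 gives 120 nM. For compound 2 the value reported, > 10000 nM, is a limit of the assay rather than a number. The same holds for compound 3, whose > 10000 nM is also a limit. Compound 2 thus stands at the weak end of what has been measured here, as described by the limit of > 10000 nM in this assay, at which 2 of the 3 values shown sit.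

The unmeasured compound 4, `Cn1cncc1[C@H]1OC(C)(C)OC[C@H]1C/C=C\CCC(=O)O`, differs from compound 2 in one place: 1-methyl-1H-imidazol-5-yl in place of pyrazin-2-yl on a saturated ring carbon. The measured steps that bear on this are an at least 83-fold higher number from compound 1 to compound 2 (1.92 log units; beyond the scatter) and an at least 83-fold higher number from compound 1 to compound 3 (1.92 log units; beyond the scatter), both large losses when the pyridin-3-yl of compound 1 is exchanged for another heteroaryl group. The step between compound 2 and compound 3, a step that the two limits leave unreadable from compound 2 to compound 3, gives no readable size. Within the data shown here, no measured step shows what the 1-methyl-1H-imidazol-5-yl group itself does in this assay, so only a broad expectation is possible. Compound 4 is estimated at 3000 nM, within a range from 300 nM to 10000 nM. This expected value corresponds to an at least 3.3-fold lower number from compound 2 to compound 4 (0.52 log units; beyond the scatter), with a fair chance that only a limit is reported again.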

Compound 4, half-maximal inhibitory concentration: 70 nM
Beside the measured number, compound 4's estimate is 43-fold (1.63 log units) above it, and the stated range ends above it.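

On the saturated ring carbon, 1-methyl-1H-imidazol-5-yl in place of pyrazin-2-yl gives an at least 140-fold lower number from compound 2 to compound 4 (2.15 log units; beyond the scatter), and in place of 1,3-oxazol-5-yl it gives an at least 140-fold lower number from compound 3 to compound 4 (2.15 log units; beyond the scatter). So this position does not simply reject every group other than pyridin-3-yl: in this assay, the exchange of pyridin-3-yl for 1-methyl-1H-imidazol-5-yl gives a 1.7-fold lower number from compound 1 to compound 4 (0.23 log units; within the scatter), which leaves the two groups level. Ring size does not sort the results either, as five-membered rings appear in compound 3 and compound 4 and six-membered rings in compound 1 and compound 2, while the weak pair stays at a limit of the assay: the limit of > 10000 nM in this assay, at which 2 of the 4 values shown sit.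

The step between compound 2 and compound 3 cannot be read, as both values are limits. On these data alone, whether the methyl group on the imidazole matters, as a comparison with plain 1H-imidazol-5-yl would show, and how a thiazol-5-yl group would behave here both remain open.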